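Replacing the Bromo-Methoxy Ring in a Growth Inhibitor

The source may report more compounds than this note shows. Statements on the series, on what has been measured and on what is new or still open speak of the compounds shown alone.

In a functional assay on U-251 cells (Homo sapiens) for cytotoxicity (a lower number here means a stronger inhibitor of growth, a higher number a weaker inhibitor of growth), compound 1 `COc1ccc(C2=C(c3ccc(SC)cc3)CC3CCCN3C2=O)cc1OC(=O)CNC(=O)OC(C)(C)C` gives 6000 nM and compound 2 `COc1ccc(C2=C(c3ccc(SC)cc3)CC3CCCN3C2=O)cc1OC(=O)C1CCCN1C(=O)OC(C)(C)C` gives 2000 nM. Compound 3 `COc1ccc(C2=C(c3ccc(SC)cc3)CC3CCCN3C2=O)cc1Br` gives 800 nM, the lowest of the three numbers and so the strongest growth inhibition measured so far.

Compound 4 `CSc1ccc(C2=C(c3ccc(C)c(C)c3)C(=O)N3CCCC3C2)cc1` carries 3,4-dimethylphenyl in place of 3-bromo-4-methoxyphenyl on a double-bonded ring carbon. Among the compounds with values here, two measured steps bear on this, since both alter a group on that same aryl ring: a 3.0-fold lower number from compound 1 to compound 2 (0.48 log units; beyond the scatter) and a 7.5-fold lower number from compound 1 to compound 3 (0.88 log units; beyond the scatter). Both are modest. Neither removes the methoxy group or adds a methyl group, so they suggest a likely size but do not settle the direction.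

Compound 3 already has the lowest number at 800 nM, so a modest rise in this assay is the cautious expectation. The expected change is a 2.3-fold higher number from compound 3 to compound 4 (0.35 log units; beyond the scatter). For compound 4 the estimated value is 1800 nM, with an expected range of 600 nM to 5000 nM.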

Compound 4, concentration for 50% growth inhibition: 10000 nM
Beside the measured number, compound 4's estimate is 5.6-fold (0.74 log units) below it, and the stated range ends below it.
By their numbers in this assay, from the lowest: compound 3; then compound 2; then compounds 1 and 4 (each within the scatter of the next).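

Exchanging the whole aryl group at this double-bonded ring carbon gives a 13-fold higher number from compound 3 to compound 4 (1.10 log units; beyond the scatter) in this assay, so growth inhibition here depends strongly on which aryl group sits at this position. Within the data shown here, this step is classed as large, whereas the earlier steps, which changed only the group on the oxygen or put a bromine in its place, were modest. Because the bromine and the methoxy group leave together, the step cannot be assigned to either one alone, and nothing available explains why the number rises.

The compounds shown leave open whether a single exchange would produce most of this loss, as with 3-methyl-4-methoxyphenyl or 3-bromo-4-methylphenyl. They also leave open how this position would respond to a ring carrying an amine or a carboxylic acid.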